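Adding a second chloro to the core of compound 2

The source may hold more compounds than are shown below. What is called first, only, known or untested is meant among the compounds shown, and "the series" means these compounds.

Measured so far, in a functional assay on ACHN cells (Homo sapiens) for cytotoxicity, read by sulforhodamine B assay, with a stated time of 48 h; a higher number here means that more compound is tolerated, a lower number that less compound is tolerated:
- compound 1 `ClCc1cccc(Cn2cnc3nc(Cl)nc(Cl)c32)c1`: 4780 nM
- compound 2 `ClCc1ccc(Cn2cnc3ncnc(Cl)c32)cc1`: "not determined" (no result reported)
- compound 3 `ClCc1cccc(Cn2cnc3ncnc(Cl)c32)c1`: 7760 nM

Compound 2 stands nowhere on these numbers: this assay gave no value for it, so it cannot be placed against compound 1 or compound 3. The step to compound 4 `ClCc1ccc(Cn2cnc3nc(Cl)nc(Cl)c32)cc1` is chloro in place of hydrogen on an aromatic carbon.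

Among the measured compounds shown here, one measured step bears on this change, run in the opposite direction: a 1.6-fold higher number from compound 1 to compound 3 (0.21 log units; within the scatter). Read backwards, putting a chloro onto the core moved the number little and stayed within the scatter. For the measured compounds named here, compound 4 carries the same two chloro groups on the core as compound 1, and compound 1 is the only measured compound with that arrangement; the benzyl arm is attached differently, and no measured pair shows what that does. So the expectation for compound 4 is no step beyond the scatter in this assay relative to compound 1, and no anchor exists for a step from compound 2.

Compound 4 is expected to give about 4800 nM because compound 1 gives 4780 nM, with a range from 1800 nM to 13000 nM that is estimated to be wide owing to the missing number for compound 2.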

Compound 4, concentration lethal to 50% of the cells: 5750 nM
Compound 4: the middle estimate sits 1.2-fold (0.08 log units) below what was measured; low and high end bracket the measured number.
By their numbers in this assay, from the lowest: compounds 1, 4 and 3 (each within the scatter of the next).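

Among the compounds shown here, no step from compound 2 to compound 4 can be read: in this assay compound 2 has no number to set against compound 4 at 5750 nM. The compounds shown leave open what the chloro between two ring nitrogen atoms does with the benzyl arm attached as in compound 4. Nothing shown offers an explanation for this value.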